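The source may hold more compounds than are shown below. What is called first, only, known or untested is meant among the compounds shown, and "the series" means these compounds.

Of the compounds shown here, three built on one shared core have been measured in an ADME assay (Rattus norvegicus, strain Wistar Han) for pharmacokinetics; a lower number here means that more of the compound stays in the plasma, a higher number that more of the compound sits outside the plasma. Compound 1 `CCn1c(-c2cnc(C)nc2)nc2c(N[C@H]3CCN(C(=O)c4cocn4)C3)ncnc21` gives 6.1 L/kg. Compound 2 `CCC(=O)N1CC[C@H](Oc2ncnc3c2nc(-c2cnc(C)nc2)n3CC)C1` gives 2.4 L/kg. Compound 3 `CCn1c(-c2ccc(C(F)(F)F)nc2)nc2c(O[C@H]3CCN(C(=O)[C@H]4C[C@@H](OC)C4)C3)ncnc21` gives 1.3 L/kg. Compound 2 thus holds the second highest of the three numbers: it sits within the scatter of compound 3, so no order between those two can be read, while compound 1 stands beyond the scatter with the higher number.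

Compound 4 `CCn1c(-c2cnc(C)nc2)nc2c(O[C@H]3CCN(C(=O)C4CCOC4)C3)ncnc21` has not yet been measured. It differs from compound 2 in a single place: oxolan-3-yl in place of ethyl on a carbonyl carbon. Going by the values given here, no measured pair shows this exact change, so its effect can only be guessed. Compound 3 carries a different amide group than compound 2 and gives the lower number, but compound 3 also carries a different group on the shared core, so the two changes cannot be separated. The step of a 1.1-fold lower number from compound 2 to compound 4 (0.04 log units; within the scatter) is what is expected here, modest in size or none beyond the scatter. Compound 4 is therefore expected to give about 2.2 L/kg, with a range from 1.1 L/kg to 4.4 L/kg.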

Compound 4, volume of distribution: 0.9 L/kg
Estimate against measurement, compound 4: 2.4-fold (0.39 log units) above; measured number outside the range, below it.
By their numbers in this assay, from the lowest: compounds 4, 3 and 2 (each within the scatter of the next, the first and the last beyond it); then compound 1.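

Going by these compounds alone, the step from ethyl to oxolan-3-yl on a carbonyl carbon is the first change here that can be read on its own, as every other group stays the same: in this assay it gives a 2.7-fold lower number from compound 2 to compound 4 (0.43 log units; beyond the scatter) and lies beyond the usual scatter. This shows that the group on this carbonyl carbon, whose other neighbour is the amide-type nitrogen in a ring, can by itself shift the read-out, which compound 3 could not show with its second change on the shared core. No measurement shown here accounts for the shift.

The incoming group adds both a ring and an oxygen, so cyclopentyl, with the ring alone, or a methoxyethyl chain, with the oxygen but no ring, would be needed to tell those apart. Going by these compounds, whether the step holds with other groups on the shared core also stays open.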